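The source may hold more compounds than are shown below. What is called first, only, known or untested is meant among the compounds shown, and "the series" means these compounds.

Values in a functional assay, read by spectrophotometry, with a stated time of 6 min (a lower number here means a stronger inhibitor, a higher number a weaker inhibitor), for the series so far
- Compound 1 `CCCCCCCCOc1cc(OC)c(Br)cc1C(C)=O` gives 32000000 nM
- Compound 2 `CCCCOc1cc(OC)ccc1C(C)=O` gives 36300000 nM
- Compound 3 `CCCCCCCCOc1cc(OC)ccc1C(C)=O` gives 38300000 nM

Compound 3 sits level with the other two, as a 1.2-fold higher number from compound 1 to compound 3 (0.08 log units; within the scatter) and a 1.1-fold higher number from compound 2 to compound 3 (0.02 log units; within the scatter) show. Compound 4 `CCCCCCCCCCCCCCOc1cc(OC)ccc1C(C)=O` differs from compound 3 on the chain alone (hexyl in place of hydrogen on a saturated chain carbon, eight bonds along the chain from an oxygen on an aromatic ring). Among the measured compounds shown here, the closest precedent is the one measured chain change, a 1.1-fold higher number from compound 2 to compound 3 (0.02 log units; within the scatter) and the bromo step bears on it less directly. No chain longer than that of compound 3 has been measured, so this is an extrapolation. No step beyond the scatter is expected in this assay for this change. The estimated step is a 1.3-fold lower number from compound 3 to compound 4 (0.11 log units; within the scatter) and it rests on that precedent alone. For compound 4 the expected value is 30000000 nM (estimated range 12000000 nM to 60000000 nM).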

Compound 4, half-maximal inhibitory concentration: 38000000 nM
The estimate for compound 4 lay 1.3-fold (0.10 log units) below the measured number; the measured number falls inside the stated range.
By their numbers in this assay, from the lowest: compounds 1, 2, 4 and 3 (each within the scatter of the next).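

In this assay, hexyl in place of hydrogen on a saturated chain carbon, eight bonds along the chain from an oxygen on an aromatic ring, gives a 1.0-fold lower number from compound 3 to compound 4 (0.00 log units; within the scatter). The earlier chain step stopped at compound 3, whereas compound 4 shows that this further extension also produces no step beyond the scatter. No available evidence accounts for this flat result. Still open, as far as these compounds go, is whether an amine or a carboxylic acid in place of the hexyl would separate from this level.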